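A few compounds are considered here, and "the series" means these few. Any claim that something is new, unique, unknown or untested is made for them only; others in the source may bear on it.

Compound 1 `Cc1ccccc1OCCCO` gives 2.34
Compound 2 `CC(O)COc1ccc(Cl)cc1` gives 2.16

Both numbers come from a physicochemical assay for lipophilicity, measured as octanol-water partition; a higher number here means a more lipophilic compound, a lower number a more polar compound. The values of compound 2 and compound 1 lie within the usual scatter of repeated measurements, so these two cannot be told apart on this evidence.

Compound 3 `OCCCOc1ccc(Cl)cc1` has the same atoms as compound 2, joined differently: 2-hydroxyethyl in place of 1-hydroxyethyl on a saturated chain carbon bound to an oxygen on an aromatic ring. Cut one bond further out, the same difference reads 2-hydroxypropyl to 3-hydroxypropyl. Small rearrangements of this kind are easy to overlook, yet they still need to be measured.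

Going by the values given here, no measured pair shows this change, so there is no direct precedent for its size. Compound 1 offers only loose guidance, since it carries a 3-hydroxypropyl chain on a different core and gives 2.34. A small rise in this assay is expected, one that stays within the scatter. The estimated size of this change is a number 0.14 log units higher from compound 2 to compound 3 (within the scatter). For compound 3 the expected value is 2.3, with an estimated range from 2.05 to 2.55.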

Compound 3, partition coefficient: 2.36
Estimate against measurement, compound 3: 0.06 log units below; low and high end bracket the measured number.
By their numbers in this assay, from the lowest: compounds 2, 1 and 3 (each within the scatter of the next).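

In this assay, going by these compounds alone, putting 2-hydroxyethyl in place of 1-hydroxyethyl on a saturated chain carbon bound to an oxygen on an aromatic ring gives a number 0.20 log units higher from compound 2 to compound 3 (within the scatter), and this is the first measured pair that isolates this change. Compound 1 has a different core and could offer only a loose hint. This pair shares one core, so the comparison concerns the rearrangement alone, and on this evidence this assay cannot tell the two arrangements apart. No measurement shown here accounts for the size of this step.

The compounds shown cover only this one rearrangement of the chain on the shared core, so it remains open whether a larger alteration at the same place would give a step beyond the scatter. As far as these compounds go, an amine or a carboxylic acid in place of the hydroxyl, or a longer chain carrying it, would test that, and whether the same rearrangement behaves alike on the core of compound 1 also remains open.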